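The compounds below may be only part of what the source reports. "The series", "measured", "known", "first", "only" and "open" are said of these compounds alone.

Compound 3, `Cc1ccc2[nH]c(=O)c(-c3nc4cc(F)ccc4[nH]3)cc2c1`, is known in an ADME assay on L02 cells (Homo sapiens) for cytotoxicity, read by MTT assay, with a stated time of 48 h (a lower number here means a stronger inhibitor, a higher number a weaker inhibitor), only as a limit. In this assay compound 3 gives > 100000 nM, which is a limit of the assay and not a measured number. Two related compounds stand at the same point. Compound 1, `Cc1ccc2[nH]c(=O)c(-c3nc4cc([N+](=O)[O-])ccc4[nH]3)cc2c1`, gives > 100000 nM in this assay, again a limit. Compound 2, `COc1ccc2[nH]c(=O)c(-c3nc4cc(Cl)ccc4[nH]3)cc2c1`, gives > 100000 nM in this assay, also a limit. Among the measured compounds shown here, all three values sit at the limit of > 100000 nM in this assay, at which 3 of the 3 values shown sit, so that no step between any two of them can be read; the one measured step that touches the same position as the change described next, a step that the two limits leave unreadable from compound 1 to compound 3, has a limit at both ends and its size is not readable.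

Compound 4, `Cc1ccc2[nH]c(=O)c(-c3nc4cc(Cl)ccc4[nH]3)cc2c1`, differs from compound 3 in one place: chloro in place of fluoro on an aromatic carbon. For the measured compounds named here, no measured step bears on this change with a readable size. For compound 4 the expectation in this assay is therefore no step beyond the usual scatter, with a fourth value most likely again at the limit. Compound 4 is expected at 150000 nM, in a range from 50000 nM to 500000 nM. The expected step that the limit leaves unreadable from compound 3 to compound 4 is thus taken to stay within the scatter.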

Compound 4, half-maximal inhibitory concentration: > 100000 nM
Compound 4 ended at the assay's limit; the forecaster's own chance of this, stated with the estimate: 85%; the middle value is on the limit's open side.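

Among the compounds shown here, no step from compound 1, compound 2 or compound 3 to compound 4 can be read in this assay, since each value is a limit of the assay and not a number: the limit of > 100000 nM in this assay, at which 4 of the 4 values shown sit.

These compounds leave open where their true values lie and whether swapping chloro, fluoro, nitro, methyl or methoxy changes them at all.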